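This account rests on a few compounds, and the source may have more. Where it says the series, first, only, none or still open, it means among the compounds named here.

In a functional assay on PLC5 cells (Homo sapiens) for cytotoxicity, read by MTT assay (on this read-out lower numbers stand for stronger inhibition and higher numbers for weaker inhibition), three compounds carry results so far. Compound 1 `COc1cc(-c2cc3ccccc3[nH]2)[nH]c1C=C1SCCCS1` reaches only a limit of the assay, > 40000 nM, which is the limit of > 40000 nM in this assay, at which 1 of the 3 values shown sits. Compound 2 `COC1=CC(c2cc3ccccc3[nH]2)=N/C1=C\c1ccc(-c2cc3ccccc3[nH]2)[nH]1` gives 15900 nM. Compound 3 `COC1=CC(c2cc3cc(Br)ccc3[nH]2)=N/C1=C\c1ccc[nH]1` gives 6300 nM, the lowest of the two numbers, with compound 2 standing at a higher number by more than the scatter.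

Compound 4 `COC1=CC(c2cc3ccccc3[nH]2)=N/C1=C\c1ccc[nH]1` differs from compound 3 in one place: hydrogen in place of bromo on an aromatic carbon. Among the measured compounds shown here, no pair among the measured compounds shows the effect of such a change, so no measured step guides the expectation. For compound 4 a value of 10000 nM is estimated, with a range from 4000 nM to 25000 nM. The expected step of a 1.6-fold higher number from compound 3 to compound 4 (0.20 log units; within the scatter) is a modest rise in the number, close to the edge of the scatter.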

Compound 4, half-maximal inhibitory concentration: 13200 nM
The estimate for compound 4 lay 1.3-fold (0.12 log units) below the measured number; the measured number falls inside the stated range.
By their numbers in this assay, from the lowest: compound 3; then compounds 4 and 2 (each within the scatter of the next). At a limit, above all of these: compound 1.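

In this assay, hydrogen in place of bromo on the six-membered aromatic ring gives a 2.1-fold higher number from compound 3 to compound 4 (0.32 log units; beyond the scatter), the first single change here shown to go beyond the scatter. Hydrogen in place of 1H-indol-2-yl on an aromatic carbon gives a 1.2-fold lower number from compound 2 to compound 4 (0.08 log units; within the scatter), so this second change stays within the scatter. Nothing measured here gives a cause for either step.

Only bromo and hydrogen can be compared at this position. From the compounds shown here alone, how chloro, methoxy or an amine on the same carbon would compare remains open.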